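Compound 3: 3-bromophenyl in place of benzyl

The source may hold more compounds than are shown below. What is called first, only, known or untested is meant among the compounds shown, and "the series" means these compounds.

Of the compounds shown here, two sharing one core have been measured so far, compound 1 (`Fc1ccccc1NC(=S)N/N=C/c1ccc2ccccc2n1`) and compound 2 (`S=C(NCc1ccccc1)N/N=C/c1ccc2ccccc2n1`). Going by the values given here, in a functional assay on SGC-7901 cells (Homo sapiens) for antiproliferative activity, read by sulforhodamine B assay, with a stated time of 72 h (on this read-out lower numbers stand for stronger inhibition and higher numbers for weaker inhibition), compound 2 gives 53700 nM, the only actual number available. In this assay compound 1 gives > 100000 nM, which is a limit of the assay and not a number.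

Next is compound 3 (`S=C(N/N=C/c1ccc2ccccc2n1)Nc1cccc(Br)c1`), in which 3-bromophenyl replaces benzyl on an amide-type nitrogen: 3-bromophenyl in place of benzyl on an amide-type nitrogen.

Among the compounds with values here, one measured step bears on this change: an at least 1.8-fold lower number from compound 1 to compound 2 (0.27 log units; that floor lies within the scatter), where benzyl replaced 2-fluorophenyl on the same nitrogen. Its floor lies within the scatter, so it fixes neither a firm size nor a firm direction. Compound 3, like compound 1, carries a substituted phenyl group at this nitrogen, which gives a mild expectation of weaker inhibition, but no step beyond the scatter is expected. The expected change is a 1.2-fold higher number from compound 2 to compound 3 (0.08 log units; within the scatter). For compound 3 the estimated value is 65000 nM, with an expected range of 20000 nM to 100000 nM.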

Compound 3, half-maximal inhibitory concentration: 78600 nM
The estimate for compound 3 lay 1.2-fold (0.08 log units) below the measured number; measured number inside the range.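

In this assay, placing 3-bromophenyl where benzyl stood on the amide-type nitrogen gives a 1.5-fold higher number from compound 2 to compound 3 (0.17 log units; within the scatter), so these two groups cannot be told apart at this nitrogen on this read-out, and the series now has a second actual number. Compound 1 remains a limit of the assay and not a number: the limit of > 100000 nM in this assay, at which 1 of the 3 values shown sits.

The comparison of the two substituted phenyl groups on this nitrogen gives an at least 1.2-fold lower number from compound 1 to compound 3 (0.10 log units; that floor lies within the scatter), and with that floor inside the scatter it fixes no direction between 3-bromophenyl and 2-fluorophenyl.

It remains open whether any group on this nitrogen can move the number beyond the scatter, since the compounds shown carry only benzyl, 3-bromophenyl and 2-fluorophenyl there. A phenyl ring bearing an amine or a carboxylic acid, or a longer chain such as phenethyl, would test this nitrogen further, and the effect of changes elsewhere on the shared core is also unknown.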